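Permeability of an oxazole-linked piperidine amide series

A few compounds are considered here, and "the series" means these few. Any claim that something is new, unique, unknown or untested is made for them only; others in the source may bear on it.

This account concerns four compounds sharing one core and follows the step from compound 3 to compound 4. Compound 1 `Cc1ccccc1-c1nc(CN2CCC(C(=O)NCCCN3CCC(C)CC3)CC2)c(C)o1` and compound 2 `Cc1ccccc1-c1nc(CN2CCC(C(=O)NCCCN3CCCCC3)CC2)c(C)o1` were both measured in a physicochemical assay for permeability, using PAMPA; on this read-out higher numbers stand for higher permeability and lower numbers for lower permeability. Compound 1 gives 425 10^-6 cm/s in this assay, and compound 2 gives 34.5 10^-6 cm/s. The only step among the measured compounds, a 12-fold lower number from compound 1 to compound 2 (1.09 log units; beyond the scatter), is a change on a saturated ring carbon and is the only step of this kind shown. Compound 3 `Cc1oc(-c2c(Cl)cccc2Cl)nc1CN1CCC(C(=O)NCCCN2C[C@H](C)C[C@H](C)C2)CC1` has no number in this assay; in this assay compound 3 is recorded as "not determined" (no result reported), so it stands nowhere on the scale shown. Compound 4 `COc1ccc(-c2nc(CN3CCC(C(=O)NCCCN4C[C@H](C)C[C@H](C)C4)CC3)c(C)o2)cc1OC` differs from compound 3 in one place: 3,4-dimethoxyphenyl in place of 2,6-dichlorophenyl on an aromatic carbon. For the measured compounds named here, no measured step bears on a change of the aryl group on the five-membered aromatic ring, so the size and direction of the step in this assay cannot be read from the data. Compound 4 is therefore expected, on the spread of the two measured numbers alone, to give about 120 10^-6 cm/s in this assay, with an estimated range from 20 10^-6 cm/s to 500 10^-6 cm/s.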

Compound 4, apparent permeability: 81.9 10^-6 cm/s
Compound 4: the middle estimate sits 1.5-fold (0.17 log units) above what was measured; the measured number falls inside the stated range.
By their numbers in this assay, from the lowest: compound 2; then compound 4; then compound 1.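

Compound 3 has no number in this assay, so the result for compound 4 (81.9 10^-6 cm/s) gives no step from compound 3 to compound 4, and no evidence available here accounts for that result. The compounds shown leave open how 3,4-dimethoxyphenyl compares with 2,6-dichlorophenyl on the shared core.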